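A few compounds are considered here, and "the series" means these few. Any claim that something is new, unique, unknown or untested is made for them only; others in the source may bear on it.

Compound 3 `CC(C)C[C@H](N)c1cc(C(F)(F)F)ccc1N1CCN(C(=O)CSc2ccc(Cl)cc2Cl)CC1` gives 1500 nM in an assay on HEK293 cells for displacement of a labelled ligand from Melanocortin receptor 4 (Homo sapiens) (a lower number here means a stronger inhibitor, a higher number a weaker inhibitor), the second highest of the three numbers seen so far: above it stands compound 1 `CC(C)C[C@H](N)c1cc(C(F)(F)F)ccc1N1CCN(C(=O)COc2ccc(O)cc2)CC1` at 4600 nM, while compound 2 `CC(C)C[C@H](N)c1cc(C(F)(F)F)ccc1N1CCN(C(=O)C(C)Cc2ccc(Cl)cc2O)CC1` lies far lower at 36 nM. The measured steps are a 3.1-fold lower number from compound 1 to compound 3 (0.49 log units; beyond the scatter), a 130-fold lower number from compound 1 to compound 2 (2.11 log units; beyond the scatter) and a 42-fold higher number from compound 2 to compound 3 (1.62 log units; beyond the scatter). Compound 4 `CC(C)C[C@H](N)c1cc(C(F)(F)F)ccc1N1CCN(C(=O)COc2ccc3ccccc3c2)CC1` differs from compound 3 by (naphthalen-2-yl)oxy in place of (2,4-dichlorophenyl)sulfanyl on a saturated chain carbon bound to a carbonyl carbon. Within the data shown here, only the step between compound 1 and compound 3 touches the same position, and it is modest; no measured compound carries the entering group anywhere, so the data give little guidance on it. The expectation for compound 4 is therefore a number near that of compound 3, no change at the digits printed from compound 3 to compound 4 (within the scatter), with wide uncertainty. Compound 4 is estimated at 1500 nM, between 300 nM and 7000 nM.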

Compound 4, inhibition constant: 2000 nM
For compound 4 the middle estimate is 1.3-fold (0.12 log units) below the measured one, and the stated range covers the measured number.
By their numbers in this assay, from the lowest: compound 2; then compounds 3 and 4 (each within the scatter of the next); then compound 1.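

In this assay, (naphthalen-2-yl)oxy in place of (2,4-dichlorophenyl)sulfanyl gives no change beyond the scatter (a 1.3-fold higher number from compound 3 to compound 4 (0.12 log units; within the scatter)), so this position tolerates that exchange of ring and linking atom together. Naphthalen-2-yl in place of 4-hydroxyphenyl is a modest step (a 2.3-fold lower number from compound 1 to compound 4 (0.36 log units; beyond the scatter)), while the gap to the 1-(4-chloro-2-hydroxybenzyl)ethyl group remains large (a 56-fold higher number from compound 2 to compound 4 (1.74 log units; beyond the scatter)). No evidence is available to explain these numbers.

Oxygen and sulfur change here along with the ring, so neither change can be read alone. Open, from the compounds shown here alone, is how a propyl chain linking the carbonyl to the naphthalene, or an amine on the naphthalene, would read.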